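Styryl butenolide series: hydroxy to methoxy on the aromatic ring

This account rests on a few compounds, and the source may have more. Where it says the series, first, only, none or still open, it means among the compounds named here.

Compound 1 `CC1(/C=C/c2ccccc2O)C=CC(=O)O1` and compound 2 `CC1(/C=C/c2cccc(O)c2)C=CC(=O)O1` share the same atoms joined differently; the difference between the two cores is not broken down here. Among the compounds with values here, in a functional assay on MCF7 cells (Homo sapiens) for inhibition, read by sulforhodamine B assay, with a stated time of 48 h (on this read-out lower numbers stand for stronger inhibition of growth and higher numbers for weaker inhibition of growth), compound 1 gives 46200 nM, and compound 2 gives 124000 nM, the highest number of the three measured so far. Compound 3 `COc1ccccc1/C=C/C1(C)C=CC(=O)O1` carries the change methyl in place of hydrogen on an oxygen on an aromatic ring relative to compound 1; in this assay compound 3 gives 27000 nM, which means a step of a 1.7-fold lower number from compound 1 to compound 3 (0.23 log units; within the scatter). Compound 4 `COc1cccc(/C=C/C2(C)C=CC(=O)O2)c1` stands to compound 2 as compound 3 stands to compound 1, the change being (methyl in place of hydrogen on an oxygen on an aromatic ring). The place of the change is described in the same words for both pairs, so this is the same change, seen twice in the set.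

Within the data shown here, only one measured instance of the change exists, and it stays within the scatter, so the expectation for compound 4 rests on a single small step. For compound 4 the step from compound 2 is expected to be a 1.7-fold lower number from compound 2 to compound 4 (0.22 log units; within the scatter) in this assay, mirroring the step between compound 1 and compound 3 of a 1.7-fold lower number from compound 1 to compound 3 (0.23 log units; within the scatter). Because compound 2 starts from 124000 nM, compound 4 is expected to remain a weak inhibitor in this assay. The estimate for compound 4 in this assay is 75000 nM, with a range from 35000 nM to 170000 nM.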

Compound 4, concentration for total growth inhibition: 25300 nM
The estimate for compound 4 lay 3.0-fold (0.47 log units) above the measured number; the measured number lies below the stated range.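

In this assay, hydroxy to methoxy on the second core gives a 4.9-fold lower number from compound 2 to compound 4 (0.69 log units; beyond the scatter), so the change does not carry over from one core to the other at a fixed size. Set beside the earlier step, the two instances differ: the same change on two cores in this assay, a 1.7-fold lower number (0.23 log units; within the scatter) from compound 1 to compound 3 and a 4.9-fold lower number (0.69 log units; beyond the scatter) from compound 2 to compound 4, 2.9-fold (0.46 log units) apart, beyond the scatter of two such steps. Both steps run towards a lower number with methoxy, but only the new one lies beyond the scatter, and two pairs neither give a rule for a further core nor explain why the size of the step depends on the core.

For this series, the working conclusion is that a methoxy step measured on one core is a poor stand-in for the size of the same step on another, and each core needs its own reading. Still open, from the compounds shown here alone, is whether a longer chain on the same oxygen, such as ethoxy, behaves like methoxy on either core, and whether an amine or a carboxylic acid on the aromatic ring in place of the hydroxy group follows the same course. Also open, going by these compounds, is whether the gap between the two steps would recur on a third core carrying a hydroxy group.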